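This account rests on a few compounds, and the source may have more. Where it says the series, first, only, none or still open, it means among the compounds named here.

In an ADME assay on BaF3 cells (Mus musculus) for cytotoxicity, read by CellTiter-Glo and CCK-8 assay, with a stated time of 72 h (a higher number here means a weaker inhibitor of growth, a lower number a stronger inhibitor of growth), compound 1 (`Cc1ccc(NC(=O)c2ccc(CN(CCN(C)C)C(=O)C3CC3)cc2)cc1Nc1nccc(-c2cccnc2)n1`) gives > 10000 nM, which is a limit and not a number. Compound 2 (`Cc1ccc(NC(=O)c2ccc(CN(CCN(C)C)C(=O)C(C)C)cc2)cc1Nc1nccc(-c2cccnc2)n1`) gives > 10000 nM, also a limit. Compound 3 (`Cc1ccc(NC(=O)c2ccc(CN(CCN(C)C)C(=O)CN(C)C)cc2)cc1Nc1nccc(-c2cccnc2)n1`) gives > 10000 nM, again a limit, so it stands with the others at the limit of > 10000 nM in this assay, at which 3 of the 3 values shown sit. Compound 4 (`C=CC(=O)N(CCN(CC)CC)Cc1ccc(C(=O)Nc2ccc(C)c(Nc3nccc(-c4cccnc4)n3)c2)cc1`) differs from it on a saturated chain carbon bound to an aromatic carbon: (2-(diethylamino)ethyl)(vinylcarbonyl)amino in place of (2-(dimethylamino)ethyl)(((dimethylamino)methyl)carbonyl)amino on a saturated chain carbon bound to an aromatic carbon. The measured changes on the carbonyl are a step that the two limits leave unreadable from compound 1 to compound 2, a step that the two limits leave unreadable from compound 1 to compound 3 and a step that the two limits leave unreadable from compound 2 to compound 3, so none offers a size to carry over. In this assay, only a small move towards stronger inhibition of growth, staying close to that limit, is expected. The expected change is an at least 1.2-fold lower number from compound 3 to compound 4 (0.09 log units; that floor lies within the scatter). For compound 4 the estimated value is 8000 nM, with an expected range of 2000 nM to 20000 nM.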

Compound 4, concentration for 50% growth inhibition: 5450 nM
Estimate against measurement, compound 4: 1.5-fold (0.17 log units) above, within the range that was stated.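

In this assay, among the compounds shown here, compound 4 alone gives a number rather than a limit, so the change on a saturated chain carbon bound to an aromatic carbon gains a size for the first time, though only as a floor: an at least 1.8-fold lower number from compound 3 to compound 4 (0.26 log units; that floor lies within the scatter), an at least 1.8-fold lower number from compound 2 to compound 4 (0.26 log units; that floor lies within the scatter) and an at least 1.8-fold lower number from compound 1 to compound 4 (0.26 log units; that floor lies within the scatter). Each floor stays within the scatter, so no real gain is established. The steps among compound 1, compound 2 and compound 3 cannot be read: the limit of > 10000 nM in this assay, at which 3 of the 4 values shown sit.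

From the compounds shown here alone, the diethylamino and vinylcarbonyl parts enter together, so which of them carries the step stays open. A (2-(dimethylamino)ethyl)(vinylcarbonyl)amino group would separate them.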